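A bromo-fluoro benzyl group replaces the methyl-substituted one

This account rests on a few compounds, and the source may have more. Where it says the series, first, only, none or still open, it means among the compounds named here.

Two compounds have been measured in a functional assay on CHO cells for positive allosteric modulation of muscarinic acetylcholine receptor M5 (Homo sapiens), read by calcium flux; on this read-out higher numbers stand for an effect only at larger amounts of compound and lower numbers for an effect already at smaller amounts:
compound 1 `COc1cccc(CN2C(=O)C(=O)c3cc(OC(F)(F)F)ccc32)c1` with 1700 nM
compound 2 `Cc1ccccc1CN1C(=O)C(=O)c2cc(OC(F)(F)F)ccc21` with 3280 nM

Compound 2 sits at one end of the two numbers shown, yet the step of a 1.9-fold higher number from compound 1 to compound 2 (0.29 log units; within the scatter) lies within the scatter, so the two compounds cannot be told apart. Compound 3 `O=C1C(=O)N(Cc2ccc(Br)cc2F)c2ccc(OC(F)(F)F)cc21` differs from compound 2 in one place: 4-bromo-2-fluorophenyl in place of 2-methylphenyl on a saturated chain carbon bound to an amide-type nitrogen in a ring. Within the data shown here, no measured step involves the 4-bromo-2-fluorophenyl group; the only measured step, the one already named, showed no change beyond the scatter. The step of a 1.3-fold lower number from compound 2 to compound 3 (0.12 log units; within the scatter) is therefore expected to stay within the scatter as well. Compound 3 is estimated at 2500 nM, with a range from 800 nM to 8000 nM.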

Compound 3, half-maximal effective concentration: > 10000 nM
Compound 3 ended at the assay's limit; the forecaster's own chance of this, stated with the estimate: 15%; at least 4.0-fold (0.60 log units) between middle value and limit.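

Compound 3 rests at a limit of the read-out and not at a number: the limit of > 10000 nM in this assay, at which 1 of the 3 values shown sits. The earlier pair could not be told apart, but this position, on a saturated chain carbon bound to an amide-type nitrogen in a ring, does not accept every substituted phenyl alike: 4-bromo-2-fluorophenyl gives an at least 3.0-fold higher number from compound 2 to compound 3 (0.48 log units; beyond the scatter) and an at least 5.8-fold higher number from compound 1 to compound 3 (0.76 log units; beyond the scatter).

The compounds shown leave open whether the bromine, the fluorine or only the two together account for this step. They also leave open how a phenyl carrying an amine or a carboxylic acid would behave here.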